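A few compounds are considered here, and "the series" means these few. Any claim that something is new, unique, unknown or untested is made for them only; others in the source may bear on it.

Compound 1 `CCCc1nc2c(C)cc(-c3nc4ccccc4n3C)cc2n1S(=O)(=O)c1ccc(OC)cc1`: 18300 nM
Compound 2 `CCCc1nc2c(C)cc(-c3nc4ccccc4n3C)cc2n1S(=O)(=O)c1ccc(Br)cc1`: 24700 nM

Going by the values given here, in a functional assay on HeLa cells (Homo sapiens) for cytotoxicity, read by MTT assay (on this read-out higher numbers stand for weaker inhibition and lower numbers for stronger inhibition), compound 1 gives the lowest of these two numbers, and the only other measured compound, compound 2, sits close to it, with a 1.3-fold higher number from compound 1 to compound 2 (0.13 log units; within the scatter). The unmeasured compound 3 `CCCc1nc2c(C)cc(-c3nc4ccccc4n3C)cc2n1S(=O)(=O)c1ccccc1Br` differs from compound 1 by 2-bromophenyl in place of 4-methoxyphenyl on a sulfonyl sulfur. Among the compounds with values here, only one measured step touches the same part of the molecule, the step from compound 1 to compound 2, which swaps groups on that phenyl ring and stayed within the scatter. Within the data shown here, compound 3 carries a different substituent at a different position of that ring, so the one known step is only a loose guide; it suggests that changes here move the number little. On that basis compound 3 is expected to lie near the two measured compounds, with a 1.3-fold higher number from compound 1 to compound 3 (0.12 log units; within the scatter). The estimate for compound 3 in this assay is 24000 nM, within a range from 10000 nM to 60000 nM.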

Compound 3, half-maximal inhibitory concentration: > 50000 nM
Compound 3: only a limit was reported (the forecaster's own chance of this, stated with the estimate: 15%); middle value at least 2.0-fold (0.31 log units) from the limit.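

In this assay compound 3 is reported only as a limit of the assay, > 50000 nM, not as an exact number. Even so, the group on the sulfonyl sulfur is shown for the first time to be able to matter: with 2-bromophenyl in place of 4-methoxyphenyl, the result is an at least 2.7-fold higher number from compound 1 to compound 3 (0.43 log units; beyond the scatter), whereas the earlier swap between compound 1 and compound 2 stayed within the scatter. Moving the bromine, from 4-bromophenyl to 2-bromophenyl, gives an at least 2.0-fold higher number from compound 2 to compound 3 (0.30 log units; that floor lies within the scatter), so this change alone is not shown to exceed the scatter.

As far as these compounds go, the true number for compound 3 remains unknown: the limit of > 50000 nM in this assay, at which 1 of the 3 values shown sits. Also open is how a 2-methoxyphenyl group or a phenyl ring carrying an amine would read on the sulfonyl sulfur, which could help separate the effect of a substituent's place from that of its kind.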